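Nitro for methyl on the benzyl arm: cytotoxicity notes

The source may hold more compounds than are shown below. What is called first, only, known or untested is meant among the compounds shown, and "the series" means these compounds.

The series shares the core of compound 2, `COC(=O)c1ccc(NCc2cncn2Cc2ccc(C)cc2)cc1-c1ccccc1`. Going by the values given here, in a toxicity assay on NIH3T3 cells (Mus musculus) for cytotoxicity, read by resazurin assay (a lower number here means that less compound is needed, a higher number that more compound is needed for the effect), compound 2 gives 50000 nM, the only plain number available. Compound 1, `Nc1cc(-c2ccccc2)ccc1Cn1cncc1CNc1ccc(Cl)c(-c2ccccc2)c1`, returns only a limit in this assay: > 1000 nM. Compound 1 thus sits at the limit of > 1000 nM in this assay, at which 1 of the 2 values shown sits. Compound 2 is therefore the single measured reference point for the next compound. Compound 3, `COC(=O)c1ccc(NCc2cncn2Cc2ccc([N+](=O)[O-])cc2)cc1-c1ccccc1`, differs from compound 2 in one place: nitro in place of methyl on an aromatic carbon. Among the compounds with values here, no pair of measured compounds carries this change, so its effect in this assay is unknown from the series itself. The step from compound 2 to compound 3 is expected to be a 1.3-fold lower number from compound 2 to compound 3 (0.10 log units; within the scatter), within the usual scatter and in no settled direction. Compound 3 is accordingly estimated at 40000 nM in this assay, with a range from 15000 nM to 100000 nM.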

Compound 3, half-maximal effective concentration: > 10000 nM
Compound 3: no number, only a limit (the forecaster's own chance of this, stated with the estimate: 20%); the middle value lies beyond the limit too.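

No step can be read between compound 2 and compound 3 in this assay. Compound 3 returns only a limit there, > 10000 nM. The compounds shown leave open whether nitro in place of methyl on an aromatic carbon changes the number, and in which direction.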